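A few compounds are considered here, and "the series" means these few. Any claim that something is new, unique, unknown or untested is made for them only; others in the source may bear on it.

Two compounds of this series carry measured numbers. For the measured compounds named here, compound 1 `COc1ccccc1/C=c1/[nH]c(=O)/c(=C\c2ccccc2OC)n(C)c1=O` and compound 2 `C=CCn1c(=O)/c(=C\c2ccccc2Cl)[nH]c(=O)/c1=C\c1ccccc1OC` share a core and differ at two places, so no single step can be drawn between them. In a functional assay on A549 cells (Homo sapiens) for cytotoxicity, read by CCK-8 assay, with a stated time of 72 h (a higher number here means a weaker inhibitor, a lower number a stronger inhibitor), compound 1 gives 7000 nM. In this assay compound 2 gives 5300 nM. Compound 2 is the compound with the smaller of the two numbers, yet the gap to compound 1 lies within the ordinary scatter of repeat measurements, so the two cannot be set apart.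

Compound 3 `C=CCn1c(=O)/c(=C\c2cccc(C)c2)[nH]c(=O)/c1=C\c1ccccc1OC` has not been measured. It differs from compound 2 in one place: 3-methylphenyl in place of 2-chlorophenyl on a double-bonded chain carbon bound to an aromatic carbon. Going by the values given here, no measured pair in the data shows what such a change does, so any expectation rests on compound 2 alone. The step from compound 2 to compound 3 is expected to be small, in no firm direction, and probably not beyond the scatter, as a 1.1-fold higher number from compound 2 to compound 3 (0.05 log units; within the scatter) states. For compound 3 the estimate in this assay is 6000 nM, with a range from 2500 nM to 15000 nM.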

Compound 3, half-maximal inhibitory concentration: 22700 nM
Estimate against measurement, compound 3: 3.8-fold (0.58 log units) below; the whole stated range lies below it.
By their numbers in this assay, from the lowest: compounds 2 and 1 (each within the scatter of the next); then compound 3.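

In this assay, for the compounds shown here, putting 3-methylphenyl in place of 2-chlorophenyl on a double-bonded chain carbon bound to an aromatic carbon gives a 4.3-fold higher number from compound 2 to compound 3 (0.63 log units; beyond the scatter), which shows that the number responds to what sits at this position, something the earlier compounds could not show with no single step between them. The response appears even though the two groups match in heavy-atom count, in their single six-membered aromatic ring of carbon only, and in having no hydrogen-bond donors, no hydrogen-bond acceptors and no net charge, so those shared counts do not settle the outcome here; the change replaces chlorine with carbon and also moves from the 2-substituted to the 3-substituted phenyl, and this one step cannot separate the two. Nothing in the available data explains the shift.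

As far as these compounds go, it remains open whether 2-methylphenyl or 3-chlorophenyl at this position would track with compound 2 or with compound 3, which would show whether the identity of the group or its place on the ring carries the step. Also open, from the compounds shown here alone, is how a phenyl ring bearing an amine or a carboxylic acid would behave here.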